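This account rests on a few compounds, and the source may have more. Where it says the series, first, only, none or still open, it means among the compounds named here.

Measured so far in a functional assay on PC-3 cells (Homo sapiens) for cytotoxicity; a lower number here means that less compound is needed, a higher number that more compound is needed for the effect:
- compound 1 `COC1=C(C)C(=O)/C(=C(O)/C=C/c2ccc(C)cc2)C(=O)C1(C)C`: 8.2 ug/mL
- compound 2 `COC1=C(C)C(=O)/C(=C(O)/C=C/c2ccccc2C)C(=O)C1(C)C`: 9 ug/mL
- compound 3 `COC1=C(C)C(=O)/C(=C(O)/C=C/c2cc(C)cc(C)c2)C(=O)C1(C)C`: 8.8 ug/mL

In this assay compound 3 gives 8.8 ug/mL, which lies within the scatter of both other compounds, so the numbers set no order among the three.

The next compound, compound 4 `COC1=C(C)C(=O)/C(=C(O)/C=C/c2ccco2)C(=O)C1(C)C`, keeps the shared core and changes only the aromatic group on a double-bonded chain carbon bound to a double-bonded chain carbon: furan-2-yl in place of 3,5-dimethylphenyl on a double-bonded chain carbon bound to a double-bonded chain carbon.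

Among the measured compounds shown here, three measured steps bear on this change, and each exchanges one methyl-bearing phenyl group for another: a 1.1-fold higher number from compound 1 to compound 2 (0.04 log units; within the scatter), a 1.1-fold higher number from compound 1 to compound 3 (0.03 log units; within the scatter) and a 1.0-fold lower number from compound 2 to compound 3 (0.01 log units; within the scatter). All of them stay within the scatter. For the measured compounds named here, none of them, however, leaves the phenyl series, and no measured compound carries furan-2-yl, so they are only indirect guidance for this exchange. Going by these compounds, with that caveat, no shift beyond the scatter is expected, and the direction stays open. The expected size is a 1.1-fold higher number from compound 3 to compound 4 (0.06 log units; within the scatter). For compound 4 the estimated value is 10 ug/mL, with an expected range from 5 ug/mL to 20 ug/mL.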

Compound 4, concentration for half-maximal effect: 20.6 ug/mL
Beside the measured number, compound 4's estimate is 2.1-fold (0.31 log units) below it; the measured number lies above the stated range.
By their numbers in this assay, from the lowest: compounds 1, 3 and 2 (each within the scatter of the next); then compound 4.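

Among the methyl-bearing phenyl compounds, moving or adding methyl groups left the number within the scatter, but replacing the phenyl ring itself at this position gives the first clear shift in this assay: a 2.3-fold higher number from compound 3 to compound 4 (0.37 log units; beyond the scatter), a 2.3-fold higher number from compound 2 to compound 4 (0.36 log units; beyond the scatter) and a 2.5-fold higher number from compound 1 to compound 4 (0.40 log units; beyond the scatter). The three steps are modest and similar in size, and each one shows that the position on a double-bonded chain carbon bound to a double-bonded chain carbon does respond to the choice of aromatic group, with more compound needed once furan-2-yl is in place. Several things change together in this exchange, since a six-membered aromatic ring of carbon only gives way to a five-membered aromatic ring with 1 hetero atom and the methyl groups are lost, and no measurement at hand shows which of these differences accounts for the shift.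

Going by these compounds, what a thiophen-2-yl or a pyridin-2-yl group would give at this place remains open, so the shift cannot yet be tied to furan-2-yl alone rather than to leaving the phenyl series. Also open, on these data alone, is whether a phenyl ring bearing a methoxy group or an amine would stay level with compound 1, compound 2 and compound 3 or move toward compound 4.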